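The source may hold more compounds than are shown below. What is called first, only, known or untested is meant among the compounds shown, and "the series" means these compounds.

Measured in a functional assay on A549 cells (Homo sapiens) for cytotoxicity, read by WST assay, with a stated time of 48 h; a higher number here means a weaker inhibitor, a lower number a stronger inhibitor:
compound 1 `COc1ccc2c(/C=C(\C#N)C(=O)c3c[nH]c4cc(F)ccc34)c[nH]c2c1`: 5500 nM
compound 2 `COc1ccc2[nH]cc(/C=C(\C#N)C(=O)c3c[nH]c4ccccc34)c2c1`: 13700 nM

In this assay compound 1 gives 5500 nM and compound 2 gives 13700 nM. Compound 1 has the lower of the two numbers, and the gap between them lies beyond the scatter. Compound 3 `COc1ccc2c(/C=C(\C#N)C(=O)c3c[nH]c4cc(OC)ccc34)c[nH]c2c1` is the next to read. It keeps the core of compound 1 and carries methoxy in place of fluoro on an aromatic carbon. Among the measured compounds shown here, no measured pair isolates this change. Compound 2 has no fluoro and gives 13700 nM, but it also differs from compound 1 elsewhere, so it offers only a loose guide. A modest move toward a higher number is therefore expected, possibly no larger than the scatter. The expected step is a 1.5-fold higher number from compound 1 to compound 3 (0.19 log units; within the scatter). The estimate for compound 3 is 8500 nM, with an expected range of 3000 nM to 24000 nM.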

Compound 3, half-maximal inhibitory concentration: 1700 nM
The estimate for compound 3 lay 5.0-fold (0.70 log units) above the measured number; measured number below the stated range.
By their numbers in this assay, from the lowest: compound 3; then compound 1; then compound 2.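

In this assay, methoxy in place of fluoro on an aromatic carbon gives a 3.2-fold lower number from compound 1 to compound 3 (0.51 log units; beyond the scatter). Among the compounds shown here, this is the first direct reading at this position, meta to a fused ring and para to a fused ring, and it shows that the number responds to the group held there on an otherwise unchanged core, with fluoro not needed for the lower value. No available evidence bears on the reason for this step.

For the compounds shown here, the single pair leaves open whether the shift is particular to methoxy or extends to other groups on this carbon, such as hydroxy, an amine or a longer alkoxy chain like ethoxy. It also leaves open how either group compares with plain hydrogen at this position on the same core, since compound 2 differs from compound 1 elsewhere as well.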